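Bromophenyl to Nitrophenyl on a Sulfonamide Cap

The compounds below may be only part of what the source reports. "The series", "measured", "known", "first", "only" and "open" are said of these compounds alone.

Measured compounds:
compound 1 `CN(C(=O)c1ccc(F)cc1)c1ccc2[nH]c(-c3n[nH]c4ccccc34)cc2n1`, with 7220 nM in a functional assay on KB cells (Homo sapiens) for antiproliferative activity, read by MTT assay, with a stated time of 72 h; a higher number here means a weaker inhibitor, a lower number a stronger inhibitor
compound 2 `CN(c1ccc2[nH]c(-c3n[nH]c4ccccc34)cc2n1)S(=O)(=O)c1ccc(Br)cc1`, with 7150 nM in this assay

Among the compounds with values here, compound 2 carries the lowest of the two numbers so far, but its nearest neighbour, compound 1, sits within the scatter of it: the one step seen, a 1.0-fold lower number from compound 1 to compound 2 (0.00 log units; within the scatter), did not move the number beyond the noise.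

Compound 3 `CN(c1ccc2[nH]c(-c3n[nH]c4ccccc34)cc2n1)S(=O)(=O)c1cccc([N+](=O)[O-])c1` is the next member of the series. It differs from compound 2 in one place: 3-nitrophenyl in place of 4-bromophenyl on a sulfonyl sulfur. Within the data shown here, the only measured step concerns a different position, the group on the sulfonamide nitrogen rather than the aryl on the sulfonyl sulfur, so it bears on this change only indirectly; what it shows is that swapping one aromatic cap for another left this assay unchanged within the scatter. Among the measured compounds shown here, no step of any size is therefore expected in this assay for compound 3, and the estimate is a 1.0-fold lower number from compound 2 to compound 3 (0.01 log units; within the scatter). Compound 3 is expected to give about 7000 nM, with a range from 3000 nM to 16000 nM.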

Compound 3, half-maximal inhibitory concentration: 5870 nM
Compound 3: the middle estimate sits 1.2-fold (0.08 log units) above what was measured; low and high end bracket the measured number.
By their numbers in this assay, from the lowest: compounds 3, 2 and 1 (each within the scatter of the next).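

Within the data shown here, for the first time the aryl on the sulfonyl sulfur itself can be read: the change from 4-bromophenyl to 3-nitrophenyl (a 1.2-fold lower number from compound 2 to compound 3 (0.09 log units; within the scatter)) in this assay stays within the scatter. Among these compounds, the earlier step concerned the group on the sulfonamide nitrogen, so this is the first sign that the sulfonyl position accepts a different aryl without a clear shift, even though the entering group brings hydrogen-bond acceptors that the leaving group lacks. Nothing at hand gives a reason for this result.

The compounds shown carry only aromatic groups on the sulfonyl sulfur, so it stays open whether an amine, a carboxylic acid or an open alkyl chain there would move the number beyond the scatter. Equally open, going by these compounds, is whether a longer chain in place of the methyl on the sulfonamide nitrogen would leave the number where it is.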